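Swapping a pyrazole for a triazole on the amide arm

The source may hold more compounds than are shown below. What is called first, only, known or untested is meant among the compounds shown, and "the series" means these compounds.

Measured so far:
compound 1 `CCOc1ncc(-c2nc(C(F)(F)F)sc2N2CCN(C(=O)Cn3cnc4cccnc43)[C@H](C)C2)cn1` gives 2 nM
compound 2 `CCOc1ncc(-c2nc(C(F)(F)F)sc2N2CCN(C(=O)Cn3ccc4cnccc43)[C@H](C)C2)cn1` gives 3.6 nM
compound 3 `CCOc1ncc(-c2nc(C(F)(F)F)sc2N2CCN(C(=O)Cn3nccc3C)[C@H](C)C2)cn1` gives 2 nM

In a functional assay on CHO-K1 cells for antagonist activity at C-X-C chemokine receptor type 3 (Homo sapiens), read by FLIPR, with a stated time of 10 min (on this read-out lower numbers stand for stronger inhibition and higher numbers for weaker inhibition), compound 3 gives 2 nM. Compound 3 stands level with compound 1 at the digits shown, the two of them together the lowest of the three numbers, while a 1.8-fold lower number from compound 2 to compound 3 (0.26 log units; within the scatter). All three compounds share one core and differ only in the aromatic group hung on a saturated chain carbon bound to a carbonyl carbon.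

Compound 4 `CCOc1ncc(-c2nc(C(F)(F)F)sc2N2CCN(C(=O)Cn3nc(C)nc3C)[C@H](C)C2)cn1` has not yet been measured. It differs from compound 3 in one place: 3,5-dimethyl-1H-1,2,4-triazol-1-yl in place of 5-methyl-1H-pyrazol-1-yl on a saturated chain carbon bound to a carbonyl carbon. The steps already seen at this very place bear on it: no change at the digits printed from compound 1 to compound 3 (within the scatter), a 1.8-fold higher number from compound 1 to compound 2 (0.26 log units; within the scatter), and a 1.8-fold lower number from compound 2 to compound 3 (0.26 log units; within the scatter). Each of those changes was larger than the present one, yet none moved the number beyond the scatter. The expectation is therefore that compound 4 will show a 1.3-fold higher number from compound 3 to compound 4 (0.10 log units; within the scatter), with no step beyond the scatter in either direction. The estimate for compound 4 in this assay is 2.5 nM, with a range from 1 nM to 7 nM.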

Compound 4, half-maximal inhibitory concentration: 7 nM
The estimate for compound 4 lay 2.8-fold (0.45 log units) below the measured number; the range from low to high includes it.
By their numbers in this assay, from the lowest: compounds 1, 3, 2 and 4 (each within the scatter of the next, the first and the last beyond it).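

In this assay the aromatic group on a saturated chain carbon bound to a carbonyl carbon can move the number beyond the scatter after all, with a 3.5-fold higher number from compound 3 to compound 4 (0.54 log units; beyond the scatter) for the smallest change of group seen so far. Against the larger two-ring group, a 3.5-fold higher number from compound 1 to compound 4 (0.54 log units; beyond the scatter) also lies beyond the scatter, whereas a 1.9-fold higher number from compound 2 to compound 4 (0.29 log units; within the scatter) stays within it, so compound 2 and compound 4 cannot be put in order.

Compound 4 differs from compound 3 in both the ring and an added methyl, so 3,5-dimethyl-1H-pyrazol-1-yl or 5-methyl-1H-1,2,4-triazol-1-yl at this place would be needed to separate the two changes. No measurement shown here speaks to what lies behind the step.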